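Thiophen-2-yl in place of 3,5-dimethylphenyl: step to compound 3

The source may hold more compounds than are shown below. What is called first, only, known or untested is meant among the compounds shown, and "the series" means these compounds.

In a functional assay on BaF3 cells (Mus musculus) for inhibition, read by MTT assay, with a stated time of 3 days (on this read-out higher numbers stand for weaker inhibition of growth and lower numbers for stronger inhibition of growth), compound 1 `O=C(Nc1ccc(Br)cc1)Nc1ccc(Nc2ncnc3c2OCCN3)cc1` gives 10000 nM. Compound 2 `Cc1cc(C)cc(NC(=O)Nc2ccc(Nc3ncnc4c3OCCN4)cc2)c1` gives > 10000 nM, which is a limit of the assay and not a number. Among the compounds with values here, the only measured step, a number no lower from compound 1 to compound 2 (the limit leaves the size open), has no readable size. Compound 3 `O=C(Nc1ccc(Nc2ncnc3c2OCCN3)cc1)Nc1cccs1` follows from compound 2 by thiophen-2-yl in place of 3,5-dimethylphenyl on an amide-type nitrogen, with thiophen-2-yl in place of 3,5-dimethylphenyl on an amide-type nitrogen. The expected step is an at least 1.2-fold lower number from compound 2 to compound 3 (0.09 log units; that floor lies within the scatter), no larger than the scatter and with no firm direction. For compound 3 the estimated value in this assay is 8000 nM, with an expected range of 3000 nM to 12000 nM.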

Compound 3, concentration for 50% growth inhibition: > 10000 nM
Compound 3 ended at the assay's limit; the forecaster's own chance of this, stated with the estimate: 50%; at least 1.2-fold (0.09 log units) between middle value and limit.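

In this assay compound 3 gives > 10000 nM, a limit of the assay and not a number. Thiophen-2-yl, a five-membered aromatic ring with 1 hetero atom, thus reaches the same limit as the 3,5-dimethylphenyl of compound 2, so the series now shows this outcome with two different ring types on the amide-type nitrogen. Thiophen-2-yl in place of 4-bromophenyl gives a number no lower from compound 1 to compound 3 (the limit leaves the size open) on the amide-type nitrogen. The step from compound 2 to compound 3 cannot be read because the values stop at the limit: the limit of > 10000 nM in this assay, at which 2 of the 3 values shown sit.

On these data alone, whether an aminoalkyl chain or a carboxylic acid on the amide-type nitrogen would give a value that can be read remains open.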